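This account rests on a few compounds, and the source may have more. Where it says the series, first, only, none or still open, it means among the compounds named here.

Measured compounds:
- compound 1 `Cc1n[nH]c2ccc(-c3nc4cnc(N5CCC(C)CC5)cn4c3Nc3ccc(Cl)cc3)cc12` — 12.6%
- compound 2 `Cc1ccc(C)c(Nc2c(-c3ccc4[nH]nc(C)c4c3)nc3cnc(N4CCN(C)CC4)cn23)c1` — "not determined" (no result reported)
- compound 3 `Cc1n[nH]c2ccc(-c3nc4cnc(N5CCN(C)CC5)cn4c3Nc3ccc(Cl)cc3Cl)cc12` — 9.53%

The series shares one core and varies the aryl group on the ring nitrogen and the saturated amine at the far end. In a functional assay on CWR22R cells (Homo sapiens) for inhibition, with a stated time of 120 h, tested at 10 uM (on this read-out lower numbers stand for less inhibition and higher numbers for more inhibition at the one concentration tested (going by the name of the read-out)), compound 1 gives 12.6%, and in this assay compound 3 gives 9.53%; the two numbers lie within the usual scatter of each other, so no order is read between them, and both sit at the low end of the read-out. Compound 2 stands nowhere on the numbers shown: in this assay compound 2 gives "not determined" (no result reported), so it gives no anchor of its own.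

Compound 4 `Cc1n[nH]c2ccc(-c3nc4cnc(N5CCN(C)CC5)cn4c3Nc3cc(Cl)ccc3Cl)cc12` differs from compound 2 in one place: 2,5-dichlorophenyl in place of 2,5-dimethylphenyl on a nitrogen on an aromatic ring. Going by the values given here, no step between measured compounds covers this exchange. On what is known, the two measured analogues of the core stay low in this assay whatever aryl group sits on the nitrogen, and nothing measured points toward a step beyond the scatter in either direction.

Compound 4 is therefore expected to give about 12% in this assay, estimated within 0% to 30%.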

Compound 4, a percentage reported as inhibition, at one concentration (the size of the read-out at that concentration, not a potency): 3.8%
Compound 4: middle estimate off by 8.2 percentage points, on the high side; the range from low to high includes it.
By their numbers in this assay, from the lowest: compounds 4, 3 and 1 (each within the scatter of the next).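

Going by these compounds alone, exchanging 2,4-dichlorophenyl for 2,5-dichlorophenyl on a nitrogen on an aromatic ring gives the first comparison at this position that changes one place only, and in this assay it reads a number 5.7 percentage points lower from compound 3 to compound 4 (within the scatter), so the two chlorine patterns cannot be told apart on this read-out. With the saturated amine at the far end held constant, the dichlorophenyl pair stays at the low end of the read-out, where compound 4 gives 3.8% and this change of chlorine pattern opens no inhibition that could be followed at the one concentration tested. No measured property or other independent information bears on the result, so it stands without an explanation.

The exchange of 2,5-dimethylphenyl for 2,5-dichlorophenyl cannot be read, since compound 2 has no number in this assay, and the effect of the far-end amine on its own also stays unresolved. On these data alone, whether this position can lift the read-out at all remains open, for example with an aryl group carrying a carboxylic acid, a primary amine or a longer alkoxy chain in place of the chlorines.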